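A few compounds are considered here, and "the series" means these few. Any claim that something is new, unique, unknown or untested is made for them only; others in the source may bear on it.

Measured so far: compound 1 `O=c1[nH]c(CN2CCCC2)nc2cc(-c3ccncc3)sc12` at 180 nM; compound 2 `Cc1nc2cc(-c3c[nH]nc3C)sc2c(=O)[nH]1` at 1500 nM; compound 3 `CCOCc1nc2cc(-c3c[nH]nc3C)sc2c(=O)[nH]1` at 2100 nM.

In an assay for inhibition of Rho-associated protein kinase 1 (Homo sapiens), read by TR-FRET, with stated times of 5 min and 2 h (on this read-out lower numbers stand for stronger inhibition and higher numbers for weaker inhibition), compound 3 gives the top number of the three, though compound 2 lies within the usual scatter of it, while compound 1 sits a step beyond the scatter lower. Compound 4 `Cc1n[nH]cc1-c1cc2nc(Cn3cccc3)[nH]c(=O)c2s1` departs from compound 3 by 1H-pyrrol-1-yl in place of ethoxy on a saturated chain carbon bound to an aromatic carbon. Within the data shown here, only one measured step touches that position: a 1.4-fold higher number from compound 2 to compound 3 (0.15 log units; within the scatter), which shows that exchanging hydrogen for ethoxy there did not move the read-out beyond the scatter. Compound 1 also carries a saturated nitrogen ring on that chain carbon, but it differs from compound 3 elsewhere as well, so its lower value cannot be assigned to that one change. Among the measured compounds shown here, with no measured step for ethoxy against 1H-pyrrol-1-yl, compound 4 is expected to show only a small move, a 1.4-fold lower number from compound 3 to compound 4 (0.15 log units; within the scatter), not clearly beyond the scatter. Compound 4 is therefore estimated at 1500 nM, with a range from 500 nM to 4500 nM.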

Compound 4, half-maximal inhibitory concentration: 370 nM
Beside the measured number, compound 4's estimate is 4.1-fold (0.61 log units) above it; the whole stated range lies above it.
By their numbers in this assay, from the lowest: compound 1; then compound 4; then compounds 2 and 3 (each within the scatter of the next).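

In this assay, the saturated chain carbon bound to an aromatic carbon proves sensitive to what it carries: 1H-pyrrol-1-yl gives a 5.7-fold lower number from compound 3 to compound 4 (0.75 log units; beyond the scatter) when it replaces ethoxy and a 4.1-fold lower number from compound 2 to compound 4 (0.61 log units; beyond the scatter) when it replaces hydrogen. Among these compounds, the earlier step at this position, a 1.4-fold higher number from compound 2 to compound 3 (0.15 log units; within the scatter) on adding ethoxy, had stayed within the scatter, so this is the first change there to pass beyond it, and it comes with a five-membered aromatic ring entering while the counts of hydrogen-bond donors and acceptors stay those of ethoxy. Nothing available explains this gain. Still open, as far as these compounds go, is whether the aromatic ring itself matters, which a phenyl group or an imidazol-1-yl group on the same chain carbon could test, and how a dimethylamino group there would compare.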